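Methyl to ethyl on the core: tolerability notes

The source may report more compounds than this note shows. Statements on the series, on what has been measured and on what is new or still open speak of the compounds shown alone.

Compound 1 `Cc1ccc2[nH]c(=O)c(CN(Cc3cccc(F)c3)Cc3ccc4ccccc4c3)cc2c1` and compound 3 `Cc1ccc2[nH]c(=O)c(CN(Cc3ccc(F)cc3)Cc3cccc4ccccc34)cc2c1` share a core whose difference is not broken down here. In a toxicity assay on MDCK cells (Canis lupus familiaris) for cytotoxicity, read by crystal violet staining, with a stated time of 48 h (a lower number here means that less compound is tolerated, a higher number that more compound is tolerated), compound 1 gives a limit of > 5000 nM. Compound 3 gives a limit of > 5000 nM in this assay. Compound 2 `CCc1ccc2[nH]c(=O)c(CN(Cc3cccc(F)c3)Cc3ccc4ccccc4c3)cc2c1` carries the change methyl in place of hydrogen on a saturated chain carbon bound to an aromatic carbon relative to compound 1; in this assay compound 2 gives a limit of > 5000 nM. The step that the two limits leave unreadable from compound 1 to compound 2 is therefore not readable, all values sitting at the limit of > 5000 nM in this assay, at which 3 of the 3 values shown sit. Compound 4 `CCc1ccc2[nH]c(=O)c(CN(Cc3ccc(F)cc3)Cc3cccc4ccccc34)cc2c1` carries the same change, (methyl in place of hydrogen on a saturated chain carbon bound to an aromatic carbon), on compound 3. For compound 4 the expected step in this assay is a step that the limit leaves unreadable from compound 3 to compound 4, resting on a step that the two limits leave unreadable from compound 1 to compound 2. Compound 4 is expected to give 8000 nM in this assay, most likely again only as a limit.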

Compound 4, half-maximal cytotoxic concentration: > 5000 nM
Compound 4: no number, only a limit; the forecaster's own chance of this, stated with the estimate: 85%; the middle value lies beyond the limit too.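

In this assay no step can be read between compound 3 and compound 4, as both values are limits: the limit of > 5000 nM in this assay, at which 4 of the 4 values shown sit.

The compounds shown leave open whether methyl to ethyl changes tolerated concentration at all.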